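A few compounds are considered here, and "the series" means these few. Any claim that something is new, unique, unknown or untested is made for them only; others in the source may bear on it.

Working notes on the series. Compound 1 `Nc1scc(CN2CCN(c3cccnc3)CC2)c1C(=O)c1ccc(Cl)cc1` is the reference point. In a functional assay on CHO cells with adenosine receptor A1 (Homo sapiens) as the target, read by cAMP accumulation and immunoassay, with a stated time of 6 min, tested at 1 uM (on this read-out higher numbers stand for a weaker effect at the one concentration tested and lower numbers for a stronger effect), compound 1 gives -2.7%. Compound 2 `Nc1scc(CN2CCN(c3cccc(F)c3)CC2)c1C(=O)c1cccc(C(F)(F)F)c1` gives -35% in this assay, and compound 3 `Nc1scc(CN2CCN(c3c(F)cccc3F)CC2)c1C(=O)c1cccc(C(F)(F)F)c1` gives 1.3%. Among the three numbers compound 1 stands second highest: compound 3 lies closest, within the scatter of it, while compound 2 lies furthest, beyond the scatter below it.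

Compound 4 `Nc1scc(CN2CCN(CCCc3ccc(Cl)cc3)CC2)c1C(=O)c1ccc(Cl)cc1` differs from compound 1 in a single place: 3-(4-chlorophenyl)propyl in place of pyridin-3-yl on an amine nitrogen in a ring. For the measured compounds named here, the only measured step touches the same ring nitrogen, a number 36.3 percentage points higher from compound 2 to compound 3 (beyond the scatter), a large move for what is a swap of one aromatic group for another at that position. Going by the values given here, it shows the position is sensitive, but no measured pair exchanges an aromatic group for a chain of this kind, so the direction for compound 4 has no direct precedent. Among the compounds with values here, the expectation for compound 4 is therefore centred near compound 1, with a wide band to cover a move of the size seen for the one measured step, expressed as a number 5.3 percentage points lower from compound 1 to compound 4 (within the scatter). Compound 4 is estimated at -8%, with a range from -45% to 25%.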

Compound 4, a percentage reported as activity, at one concentration (the size of the read-out at that concentration, not a potency): -30%
Estimate against measurement, compound 4: 22 percentage points above; measured number inside the range.
By their numbers in this assay, from the lowest: compounds 2 and 4 (each within the scatter of the next); then compounds 1 and 3 (each within the scatter of the next).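

In this assay, 3-(4-chlorophenyl)propyl in place of pyridin-3-yl on the amine nitrogen in the ring gives a number 27.3 percentage points lower from compound 1 to compound 4 (beyond the scatter), which is the direction of a stronger effect at the one concentration tested. The earlier step exchanged one aromatic group for another at this nitrogen, whereas this step shows that a group with a carbon chain leading to a chlorinated aromatic ring can enter here and still move the read-out beyond the scatter. The data shown offer no measurement that would explain this move.

This single pair changes several features at once: the chain enters, the ring nitrogen of pyridin-3-yl leaves, and a chlorine enters, so the contribution of each remains unresolved. The compounds shown leave open whether a benzyl group, an unsubstituted 3-phenylpropyl group or a longer chain ending in the same 4-chlorophenyl ring would keep this shift, and whether it would carry over to the 3-(trifluoromethyl)phenyl ketone series of the other compounds.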